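Tetrazolylmethyl to methylimidazole: expected loss of half-life

A few compounds are considered here, and "the series" means these few. Any claim that something is new, unique, unknown or untested is made for them only; others in the source may bear on it.

Compound 1 `CC(C)C(Nc1nccs1)c1ccc(-c2ccc3cccc(F)c3c2)[nH]c1=O` gives 0.07 h
Compound 2 `CC(C)C(c1ncc[nH]1)c1ccc(-c2ccc3cccc(F)c3c2)[nH]c1=O` gives < 0.0667 h, a limit of the assay
Compound 3 `CC(C)C(Cc1nnn[nH]1)c1ccc(-c2ccc3cccc(F)c3c2)[nH]c1=O` gives 2.08 h

In an ADME assay on microsomes from liver (Rattus norvegicus) for metabolic stability (on this read-out lower numbers stand for a shorter-lived compound and higher numbers for a longer-lived compound), compound 3 gives 2.08 h, the higher of the two actual numbers. Compound 4 `Cc1c[nH]c(C(c2ccc(-c3ccc4cccc(F)c4c3)[nH]c2=O)C(C)C)n1` differs from it by 4-methyl-1H-imidazol-2-yl in place of (1H-tetrazol-5-yl)methyl on a saturated chain carbon bound to an aromatic carbon and a saturated chain carbon. Compound 2 carries the unmethylated 1H-imidazol-2-yl, so the closest measured step is an at least 31-fold higher number from compound 2 to compound 3 (1.49 log units; beyond the scatter), which is large. Also large is a 30-fold higher number from compound 1 to compound 3 (1.47 log units; beyond the scatter). A similarly large fall is therefore expected, and the effect of the added methyl is unmeasured. The expected step is a 26-fold lower number from compound 3 to compound 4 (1.41 log units; beyond the scatter). For compound 4 the estimated half-life is 0.08 h, with an expected range of 0.04 h to 0.25 h.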

Compound 4, half-life: < 0.0667 h
Compound 4: no number, only a limit (the forecaster's own chance of this, stated with the estimate: 50%); middle value at least 1.1-fold (0.07 log units) from the limit.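

In this assay compound 4 gives < 0.0667 h, a limit and not a number. Changing to 4-methyl-1H-imidazol-2-yl on this carbon gives an at least 31-fold lower number from compound 3 to compound 4 (1.49 log units; beyond the scatter), so adding a methyl to the imidazole does not recover the longer half-life seen with (1H-tetrazol-5-yl)methyl. Against (1,3-thiazol-2-yl)amino the change gives an at least 1.0-fold lower number from compound 1 to compound 4 (0.02 log units; that floor lies within the scatter), and the methyl step from compound 2 to compound 4 cannot be read, as both are limits.

As far as these compounds go, whether the longer half-life belongs to the tetrazole ring or to the carbon linking it stays open. A directly bound 1H-tetrazol-5-yl or a carboxylic acid on this carbon would bear on that.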